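The source may report more compounds than this note shows. Statements on the series, on what has been measured and on what is new or still open speak of the compounds shown alone.

Compound 1 `COc1cc(/C=C/C(=O)c2cccc(NC(=O)c3cccs3)c2)ccc1O`: 0.38 ug/mL
Compound 2 `COc1cc(/C=C/C(=O)c2cccc(NC(=O)c3ccc(Cl)cc3)c2)ccc1O`: 0.76 ug/mL
Compound 3 `COc1cc(/C=C/C(=O)c2cccc(NC(=O)C(C)C)c2)ccc1O`: 1.44 ug/mL

In a functional assay on HUVEC cells (Homo sapiens) for inhibition (a higher number here means a weaker inhibitor, a lower number a stronger inhibitor), compound 1 gives the lowest of the three numbers. Compound 2 comes nearest, with a step of a 2.0-fold higher number from compound 1 to compound 2 (0.30 log units; within the scatter) that stays within the scatter, while compound 3 lies furthest, with a step of a 3.8-fold higher number from compound 1 to compound 3 (0.58 log units; beyond the scatter) that goes beyond it. Compound 4 `CCCC(=O)Nc1cccc(C(=O)/C=C/c2ccc(O)c(OC)c2)c1` has not yet been measured. It differs from compound 1 in one place: propyl in place of thiophen-2-yl on a carbonyl carbon. Going by the values given here, the step that bears most directly on this change is the one from compound 1 to compound 3, a 3.8-fold higher number from compound 1 to compound 3 (0.58 log units; beyond the scatter), where the same aromatic group at the same carbonyl carbon gave way to isopropyl, another alkyl group with no ring. The step from compound 2 to compound 3, a 1.9-fold higher number from compound 2 to compound 3 (0.28 log units; within the scatter), also exchanged a ring for an alkyl group but stayed within the scatter. A modest rise in this assay is therefore expected for compound 4, about a 3.4-fold higher number from compound 1 to compound 4 (0.53 log units; beyond the scatter). Compound 4 is estimated at 1.3 ug/mL, with a range from 0.6 ug/mL to 2.8 ug/mL.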

Compound 4, half-maximal inhibitory concentration: 1.27 ug/mL
The estimate for compound 4 lay 1.0-fold (0.01 log units) above the measured number; the range from low to high includes it.
By their numbers in this assay, from the lowest: compounds 1, 2, 4 and 3 (each within the scatter of the next, the first and the last beyond it).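

In this assay, changing the alkyl group's shape on this carbonyl carbon makes no clear difference, with a 1.1-fold lower number from compound 3 to compound 4 (0.05 log units; within the scatter). Two alkyl groups now stand beyond the scatter from the thiophen-2-yl amide, as propyl gives a 3.3-fold higher number from compound 1 to compound 4 (0.52 log units; beyond the scatter), but losing the ring is not enough to explain this pattern: compound 2 keeps a ring, yet a 1.7-fold higher number from compound 2 to compound 4 (0.22 log units; within the scatter) stays within the scatter. No supporting measurement is available to explain these differences.

The compounds shown leave open whether a longer chain such as hexyl would stay close to propyl and isopropyl, or whether another five-membered aromatic ring such as furan-2-yl would stay close to thiophen-2-yl. On these data alone, how a chain carrying an amine or a carboxylic acid would behave in this assay also remains open.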